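The source may report more compounds than this note shows. Statements on the series, on what has been measured and on what is new or still open speak of the compounds shown alone.

Compound 2 `Cc1cc(NCCO)nc(SCc2nc3ccccc3[nH]2)n1` carries a (2-hydroxyethyl)amino group on the shared core. In a functional assay on MCF7 cells (Homo sapiens) for cytotoxicity, read by MTT assay, with a stated time of 72 h (on this read-out higher numbers stand for weaker inhibition and lower numbers for stronger inhibition), compound 2 gives only a limit of the assay, > 100000 nM. Compound 1 `Cc1cc(N2CCCCC2)nc(SCc2nc3ccccc3[nH]2)n1` likewise gives only a limit in this assay, > 100000 nM. Compound 3 `Cc1cc(N2CCNCC2)nc(SCc2nc3ccccc3[nH]2)n1` also gives only a limit in this assay, > 100000 nM. All three values sit at the same limit (the limit of > 100000 nM in this assay, at which 3 of the 3 values shown sit), so compound 2 cannot be ranked against either of the other two. The change to compound 4 `Cc1cc(N(C)Cc2ccccc2)nc(SCc2nc3ccccc3[nH]2)n1` is benzyl(methyl)amino in place of (2-hydroxyethyl)amino on an aromatic carbon. Going by the values given here, two measured steps touch the same position of the core: a step that the two limits leave unreadable from compound 1 to compound 2 and a step that the two limits leave unreadable from compound 2 to compound 3, and each runs between two limits, so its size cannot be read. The step that the two limits leave unreadable from compound 1 to compound 3 is equally unreadable. Among the compounds with values here, no measured step here has a readable size, so there is no footing for expecting a change beyond the scatter from compound 2 to compound 4. The value of compound 4 is therefore expected to stay near the limit, at about 100000 nM, within a range of 20000 nM to 300000 nM. The step this estimate implies, a number no higher from compound 2 to compound 4 (the limit leaves the size open), is expected to be none beyond the scatter.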

Compound 4, half-maximal inhibitory concentration: > 100000 nM
Compound 4: only a limit was reported; the forecaster's own chance of this, stated with the estimate: 70%; the middle value sits exactly at the limit.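

Compound 4 gives only a limit in this assay, > 100000 nM, so no step from compound 1, compound 2 or compound 3 to compound 4 can be read: the limit of > 100000 nM in this assay, at which 4 of the 4 values shown sit.

The compounds shown leave open how the four rank and whether any group at this position of the shared core gives a measurable value in this assay.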